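The source may hold more compounds than are shown below. What is called first, only, known or untested is meant among the compounds shown, and "the series" means these compounds.

Measured so far in a functional assay on HepG2 cells (Homo sapiens) for antiproliferative activity, read by MTT assay, with a stated time of 72 h; on this read-out higher numbers stand for weaker inhibition and lower numbers for stronger inhibition:

Compound 1, `O=[N+]([O-])c1ccc(COc2ccc(Nc3ncnc4cc5c(cc34)OCCOCCO5)cc2)cc1`, gives > 100000 nM, which is a limit of the assay rather than a number.
Compound 2, `c1ccc(COc2ccc(Nc3ncnc4cc5c(cc34)OCCOCCO5)cc2)cc1`, gives 55500 nM.
Compound 3, `c1ccc(COc2cccc(Nc3ncnc4cc5c(cc34)OCCOCCOCCO5)c2)cc1`, gives > 100000 nM, again a limit of the assay.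

Compound 1 and compound 2 share one core and differ only by nitro in place of hydrogen on an aromatic carbon. That change produced an at least 1.8-fold higher number from compound 2 to compound 1 (0.25 log units; that floor lies within the scatter); the step is known only as a floor because of the limit of > 100000 nM in this assay, at which 2 of the 3 values shown sit. Compound 4, `O=[N+]([O-])c1ccc(COc2cccc(Nc3ncnc4cc5c(cc34)OCCOCCOCCO5)c2)cc1`, stands to compound 3 as compound 1 stands to compound 2: nitro in place of hydrogen on an aromatic carbon. The difference between the cores of compound 2 and compound 3 is not broken down here. Since compound 3 already sits at a limit, compound 4 is expected to show a step that the limit leaves unreadable from compound 3 to compound 4, most likely another limit. Compound 4 is estimated at 200000 nM, between 100000 nM and 1000000 nM.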

Compound 4, half-maximal inhibitory concentration: > 100000 nM
Compound 4: no number, only a limit; the forecaster's own chance of this, stated with the estimate: 85%; the middle value lies beyond the limit too.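

Compound 3 and compound 4 both give only a limit in this assay, so no step can be read between them: the limit of > 100000 nM in this assay, at which 3 of the 4 values shown sit.

Going by these compounds, whether nitro in place of hydrogen changes the number at all on the core of compound 3 stays open.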